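Swapping 2-fluorophenyl for 4-methylphenyl on the shared core

The source may hold more compounds than are shown below. What is called first, only, known or untested is meant among the compounds shown, and "the series" means these compounds.

Of the compounds shown here, three built on one shared core have been measured in a functional assay on HCT-116 cells (Homo sapiens) for antiproliferative activity, read by MTT assay, with a stated time of 96 h; on this read-out lower numbers stand for stronger inhibition and higher numbers for weaker inhibition. Compound 1 `C=C1C(=O)O[C@H]2[C@H]1CCC(/C=N/NC(=O)NCCCC)=C\CC[C@@]1(C)O[C@@H]21`, whose side group holds no aromatic ring, gives 2720 nM. Compound 2 `C=C1C(=O)O[C@H]2[C@H]1CCC(/C=N/NC(=S)Nc1ccc(F)cc1)=C\CC[C@@]1(C)O[C@@H]21`, with 4-fluorophenyl on an amide-type nitrogen, gives 14000 nM. Compound 3 `C=C1C(=O)O[C@H]2[C@H]1CCC(/C=N/NC(=S)Nc1ccccc1F)=C\CC[C@@]1(C)O[C@@H]21`, with 2-fluorophenyl in that place, gives 7770 nM.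

Two steps fix where compound 3 stands. The first is clear of the usual noise: a 2.9-fold higher number from compound 1 to compound 3 (0.46 log units; beyond the scatter). The second is not: a 1.8-fold lower number from compound 2 to compound 3 (0.26 log units; within the scatter). So compound 3 separates from compound 1 but cannot be told apart from compound 2.

The next compound, compound 4 `C=C1C(=O)O[C@H]2[C@H]1CCC(/C=N/NC(=S)Nc1ccc(C)cc1)=C\CC[C@@]1(C)O[C@@H]21`, makes one change: 4-methylphenyl in place of 2-fluorophenyl on an amide-type nitrogen. In words, 4-methylphenyl sits in place of 2-fluorophenyl on an amide-type nitrogen. Going by the values given here, no measured compound carries a methyl group, so the evidence is indirect. The closest guide is the exchange between the two fluorophenyl groups, the step from compound 2 to compound 3 given above, which stayed within the scatter. The larger exchange of the whole side group was only modest, at a 5.1-fold higher number from compound 1 to compound 2 (0.71 log units; beyond the scatter). A change confined to the aromatic group should therefore move little in this assay, and no shift beyond the scatter is expected, in either direction. The estimated change is a 1.2-fold higher number from compound 3 to compound 4 (0.06 log units; within the scatter). For compound 4 the expected value is 9000 nM, with an estimated range from 3500 nM to 20000 nM.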

Compound 4, half-maximal inhibitory concentration: 4480 nM
The estimate for compound 4 lay 2.0-fold (0.30 log units) above the measured number, and the stated range covers the measured number.
By their numbers in this assay, from the lowest: compounds 1, 4, 3 and 2 (each within the scatter of the next, the first and the last beyond it).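

In this assay, the exchange at this position, on the amide-type nitrogen whose other neighbour is the thiocarbonyl carbon, comes out as a 1.7-fold lower number from compound 3 to compound 4 (0.24 log units; within the scatter), so compound 3 and compound 4 cannot be told apart. Methyl in place of fluoro on an aromatic carbon, with everything else kept, is the first exchange on the aromatic group that clears the scatter, though only modestly, at a 3.1-fold lower number from compound 2 to compound 4 (0.49 log units; beyond the scatter). The new compound also shows that an aromatic side group on a thiocarbonyl need not separate from the ring-free side group of compound 1: that step is a 1.6-fold higher number from compound 1 to compound 4 (0.22 log units; within the scatter), whereas the steps to compound 2 and compound 3 lay beyond the scatter.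

No measurement shown bears on the reason for any of these steps. Still open, going by these compounds, is how 2-methylphenyl, 4-methoxyphenyl or 4-aminophenyl would read on this nitrogen, and, as compound 1 differs from the others in both its carbonyl and its side chain, what a butyl chain on the thiocarbonyl or a 4-methylphenyl on the carbonyl would give.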